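A Naphthyl Sulfonamide Tested Against a Flat Series

The compounds below may be only part of what the source reports. "The series", "measured", "known", "first", "only" and "open" are said of these compounds alone.

Compound 1 `Cc1ccc(S(=O)(=O)NC2=NCCN2C(=S)SN2CCn3c2nsc3=S)cc1` carries a 4-methylphenyl group on a sulfonyl sulfur. In a functional assay on KYSE-510 cells (Homo sapiens) for antiproliferative activity, read by crystal violet staining, with a stated time of 96 h (on this read-out higher numbers stand for weaker inhibition of growth and lower numbers for stronger inhibition of growth), compound 1 gives >= 20000 nM, which is a limit of the assay and not a number. Compound 2 `CC(=O)Nc1ccc(S(=O)(=O)NC2=NCCN2C(=S)SN2CCn3c2nsc3=S)cc1` carries acetamido in place of methyl on an aromatic carbon; in this assay compound 2 gives >= 20000 nM, again a limit rather than a number. Compound 3 `O=S(=O)(NC1=NCCN1C(=S)SN1CCn2c1nsc2=S)c1ccc(Cl)cc1Cl` carries 2,4-dichlorophenyl on the sulfonyl sulfur; in this assay compound 3 gives >= 20000 nM, also a limit. The steps a step that the two limits leave unreadable from compound 1 to compound 2, a step that the two limits leave unreadable from compound 1 to compound 3 and a step that the two limits leave unreadable from compound 2 to compound 3 therefore cannot be read because of the limit of >= 20000 nM in this assay, at which 3 of the 3 values shown sit.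

Compound 4 `O=S(=O)(NC1=NCCN1C(=S)SN1CCn2c1nsc2=S)c1ccc2ccccc2c1` differs from compound 1 in one place: naphthalen-2-yl in place of 4-methylphenyl on a sulfonyl sulfur. The measured steps concern other changes of the group on the sulfonyl sulfur, and none of them has a readable size, so they give no direction for this change. With every measured compound sitting at the limit, the expectation for compound 4 is that it also sits at the limit, and the estimated step that the limit leaves unreadable from compound 1 to compound 4 is expected to be none beyond the scatter. Compound 4 is thus estimated at 25000 nM, with a range from 8000 nM to 80000 nM.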

Compound 4, concentration for 50% growth inhibition: >= 20000 nM
Compound 4: only a limit was reported (the forecaster's own chance of this, stated with the estimate: 85%); the middle value does not contradict the limit.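

The steps linking compound 4 with compound 1, compound 2 and compound 3 cannot be read, because all of these compounds give only a limit: the limit of >= 20000 nM in this assay, at which 4 of the 4 values shown sit. The compounds shown leave open whether any change of the group on the sulfonyl sulfur alters growth inhibition in this assay.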